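The compounds below may be only part of what the source reports. "The series", "measured", "known", "first", "only" and "open" are said of these compounds alone.

In a functional assay on L02 cells (Homo sapiens) for inhibition, read by Griess assay, with stated times of 1 h and 24 h (on this read-out lower numbers stand for stronger inhibition and higher numbers for weaker inhibition), three compounds sharing one core have been read so far. Compound 1, `COc1cc(/C=C/c2nc(Nc3ccc(O)cc3)c3sccc3n2)cc(OC)c1OC`, gives > 1000000 nM, which is a limit of the assay. Compound 2, `COc1cc(/C=C/c2nc(NCc3ccc(C)cc3)c3sccc3n2)cc(OC)c1OC`, gives > 1000000 nM, again a limit. Compound 3, `COc1cc(/C=C/c2nc(NCc3ccc(Cl)cc3)c3sccc3n2)cc(OC)c1OC`, gives > 1000000 nM, also a limit, so it has no number of its own. All three stand at the limit of > 1000000 nM in this assay, at which 3 of the 3 values shown sit.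

The next structure is compound 4, `COc1cc(/C=C/c2nc(NC(C)C)c3sccc3n2)cc(OC)c1OC`, and the change reads: isopropyl in place of 4-chlorobenzyl on a nitrogen on an aromatic ring. Among the compounds with values here, three measured steps bear on it: a step that the two limits leave unreadable from compound 1 to compound 2, a step that the two limits leave unreadable from compound 1 to compound 3 and a step that the two limits leave unreadable from compound 2 to compound 3. None of them has a readable size, so there is no measured step to carry over, and isopropyl has not yet been read among these compounds. The expectation therefore rests on compound 3 and its > 1000000 nM, and no step beyond the scatter is expected in either direction, though with little confidence. The expected change is a number no higher from compound 3 to compound 4 (the limit leaves the size open). The estimate for compound 4 is 1000000 nM, with an expected range from 200000 nM to 2000000 nM, and the result may well be only a limit again.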

Compound 4, half-maximal inhibitory concentration: > 1000000 nM
Compound 4 gave a limit, no number; the forecaster's own chance of this, stated with the estimate: 75%; the middle value lies on the limit itself.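

No step can be read from compound 4 to compound 1, compound 2 or compound 3, as all four stand at one limit: the limit of > 1000000 nM in this assay, at which 4 of the 4 values shown sit.

What changing the group on the nitrogen does to inhibition in this assay stays open, with no number among the compounds shown.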